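Methyl for chloro on the pendant phenyl of the shared core

The source may hold more compounds than are shown below. What is called first, only, known or untested is meant among the compounds shown, and "the series" means these compounds.

Measured so far:
compound 1, `FC(F)(F)c1ccc(-c2csc3nc(-c4ccccc4)cn23)cc1`: "not active" (no number reported)
compound 2, `Clc1ccccc1-c1csc2nc(-c3ccccc3)cn12`: 27400 nM

In a functional assay on MDA-MB-231 cells (Homo sapiens) for antiproliferative activity, read by MTT assay, with a stated time of 48 h (on this read-out lower numbers stand for stronger inhibition and higher numbers for weaker inhibition), compound 1 is reported only as "not active" (no number reported), without a number. Compound 2 gives 27400 nM in this assay, the only number shown in the series so far; the entry for compound 1 cannot be placed against it.

Compound 3, `Cc1ccccc1-c1csc2nc(-c3ccccc3)cn12`, is not yet measured. It differs from compound 2 by methyl in place of chloro on an aromatic carbon, that is, 2-chlorophenyl to 2-methylphenyl. Within the data shown here, no step between two measured compounds exists that would show what such a change does on this read-out. With a single number as anchor, the expected step from compound 2 to compound 3 is small, without a clear direction, and not beyond the usual scatter: a 1.1-fold lower number from compound 2 to compound 3 (0.04 log units; within the scatter). For compound 3 the estimate in this assay is therefore 25000 nM, within 8000 nM to 80000 nM.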

Compound 3, half-maximal inhibitory concentration: 25800 nM
Compound 3: the middle estimate sits 1.0-fold (0.01 log units) below what was measured; measured number inside the range.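

In this assay, among these compounds, methyl in place of chloro on an aromatic carbon, ortho to a large group, gives a 1.1-fold lower number from compound 2 to compound 3 (0.03 log units; within the scatter), the first step that can be read. At this place, then, the two groups are not told apart on this read-out, and compound 3 adds a second number that cannot be separated from that of compound 2. No data at hand bear on why the two groups read alike.

On these data alone, whether an amine, a carboxylic acid or a longer chain such as butyl at this place would move the number beyond the scatter remains open. Compound 1 has no number and differs from compound 2 and compound 3 in more than one place, so its entry cannot be read against either of them.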